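Bromo position shift on the benzoyl ring of compound 3

The compounds below may be only part of what the source reports. "The series", "measured", "known", "first", "only" and "open" are said of these compounds alone.

The series shares a diacylhydrazine core. Compound 1 `Cc1ccccc1C(=O)NN(C(=O)c1ccccc1Cl)C(C)(C)C` gives 72.4 nM in an assay on cells for agonist activity at ecdysone receptor (Bombyx mori), read by a luciferase reporter, with a stated time of 24 h; on this read-out higher numbers stand for an effect only at larger amounts of compound and lower numbers for an effect already at smaller amounts. Compound 2 `CC(C)(C)N(NC(=O)c1cccc(Cl)c1)C(=O)c1ccccc1Cl` gives 155 nM in this assay, and compound 3 `CC(C)(C)N(NC(=O)c1cccc(Br)c1)C(=O)c1ccccc1Cl` gives 191 nM. Compound 3 stands with the highest number of the three; its gap to compound 2 is within the scatter, while the step of a 2.6-fold higher number from compound 1 to compound 3 (0.42 log units; beyond the scatter) is beyond it, as is the step of a 2.1-fold higher number from compound 1 to compound 2 (0.33 log units; beyond the scatter).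

Compound 4 `CC(C)(C)N(NC(=O)c1ccc(Br)cc1)C(=O)c1ccccc1Cl` is not yet measured. It differs from compound 3 by 4-bromophenyl in place of 3-bromophenyl on a carbonyl carbon. Among the measured compounds shown here, no measured step moves a group to another position on this ring, so nothing bears on the change directly. For the measured compounds named here, the nearest precedent is the step of a 1.2-fold higher number from compound 2 to compound 3 (0.09 log units; within the scatter), which shows that exchanging one halogen for another at the same place left the number within the scatter. The two modest steps from compound 1 show that this part of the molecule can shift the number, but only by a modest amount. For compound 4, a step of a 1.3-fold lower number from compound 3 to compound 4 (0.10 log units; within the scatter) in this assay is expected, which is no more than a change within or just beyond the scatter. Compound 4 is therefore estimated at 150 nM, with a range from 50 nM to 450 nM.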

Compound 4, half-maximal effective concentration: 33.9 nM
For compound 4 the middle estimate is 4.4-fold (0.65 log units) above the measured one; measured number below the stated range.
By their numbers in this assay, from the lowest: compound 4; then compound 1; then compounds 2 and 3 (each within the scatter of the next).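

In this assay, moving the bromo alone, with the same atoms on both sides, gives a 5.6-fold lower number from compound 3 to compound 4 (0.75 log units; beyond the scatter), whereas the halogen exchange gave only a 1.2-fold higher number from compound 2 to compound 3 (0.09 log units; within the scatter); at this place on the carbonyl carbon, where the halogen sits counted for more than which halogen it was. The 4-bromophenyl also changes the order of the series, with a 4.6-fold lower number from compound 2 to compound 4 (0.66 log units; beyond the scatter) and a 2.1-fold lower number from compound 1 to compound 4 (0.33 log units; beyond the scatter), so that compound 4, unlike compounds 2 and 3, carries a lower number than compound 1, and each of these steps lies beyond the scatter. No measurement at hand explains why this shift has so large an effect on the number.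

Whether the result depends on bromo itself stays open, since no other group is shown at the place that bromo takes in the 4-bromophenyl, such as an amine, a nitrile or a carboxylic acid. Also open, from the compounds shown here alone, is whether the same shift would act alike on the chloro of compound 2, or in any read-out other than this assay.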